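The compounds below may be only part of what the source reports. "The series", "measured", "known", "first", "only" and "open" are said of these compounds alone.

Measured compounds in a toxicity assay on HEK-293T cells (Homo sapiens) for cytotoxicity, read by MTT assay, with a stated time of 48 h; on this read-out lower numbers stand for stronger inhibition and higher numbers for weaker inhibition:

- compound 1 `C=C1[C@H](OC(C)=O)[C@@H](OC(C)=O)[C@@H](OC(C)=O)C(C)(C)/C=C/[C@H](C)[C@H](OC(=O)c2ccccc2)[C@@]2(O)C[C@@](C)(O)[C@H](OC(C)=O)[C@@H]2[C@H]1OCC(C)C` gives 39300 nM
- compound 2 `C=C1[C@H](OC(C)=O)[C@@H](OC(=O)c2cccc(C)c2)[C@@H](OC(C)=O)C(C)(C)/C=C/[C@H](C)[C@H](OC(=O)c2ccccc2)[C@@]2(O)C[C@@](C)(O)[C@H](OC(C)=O)[C@@H]2[C@H]1OCC(C)C` gives 4110 nM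
- compound 3 `C=C1[C@H](OC(C)=O)[C@@H](OC(C)=O)[C@@H](OC(C)=O)C(C)(C)/C=C/[C@H](C)[C@H]2O[C@]3(C)C[C@@]2(OC(=O)c2ccccc2)[C@H]([C@H]3OC(C)=O)[C@H]1OCC(C)C` gives 13500 nM

Compound 1 and compound 2 differ in one place: 3-methylphenyl in place of methyl on a carbonyl carbon. That change gave a 9.6-fold lower number from compound 1 to compound 2 (0.98 log units; beyond the scatter) in this assay, a step well beyond the scatter. Compound 3 sits on a different core; how the core of compound 3 differs from the core of compound 1 is not broken down here, and their values in this assay simply show compound 3 giving the lower number of the two.

Compound 4 `C=C1[C@H](OC(C)=O)[C@@H](OC(=O)c2cccc(C)c2)[C@@H](OC(C)=O)C(C)(C)/C=C/[C@H](C)[C@H]2O[C@]3(C)C[C@@]2(OC(=O)c2ccccc2)[C@H]([C@H]3OC(C)=O)[C@H]1OCC(C)C` is not yet measured. It carries the same change on the core of compound 3: 3-methylphenyl in place of methyl on a carbonyl carbon. The place of the change reads the same in both pairs. For the measured compounds named here, the expectation for compound 4 is a step of the same direction, a 6.8-fold lower number from compound 3 to compound 4 (0.83 log units; beyond the scatter), resting on compound 2, because a 9.6-fold lower number from compound 1 to compound 2 (0.98 log units; beyond the scatter) is the only measured instance of this change; with a different core the size is less certain, so a somewhat smaller step is assumed. Compound 4 is thus estimated at 2000 nM in this assay, with a range from 700 nM to 6000 nM.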

Compound 4, half-maximal inhibitory concentration: > 100000 nM
Compound 4 was reported as a limit; the forecaster's own chance of this, stated with the estimate: 5%; middle value at least 50-fold (1.69 log units) from the limit.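

In this assay compound 4 gives > 100000 nM, which is a limit of the assay and not a number: the limit of > 100000 nM in this assay, at which 1 of the 4 values shown sits. On the core of compound 3, 3-methylphenyl in place of methyl on a carbonyl carbon gives an at least 7.4-fold higher number from compound 3 to compound 4 (0.86 log units; beyond the scatter), so the change does not carry over from the core of compound 1 in direction: the same change on two cores in this assay, a 9.6-fold lower number (0.98 log units; beyond the scatter) from compound 1 to compound 2 and an at least 7.4-fold higher number (0.86 log units; beyond the scatter) from compound 3 to compound 4, at least 70-fold (1.85 log units) apart, beyond the scatter of two such steps. For the compounds shown here, this shows that, in these four compounds, the outcome of the change depends on the core, but with only one pair on each core it does not show which feature of the cores is responsible or how far compound 4 lies past its limit.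

The compounds shown leave open whether a longer alkyl chain or a phenyl carrying an amine, in place of 3-methylphenyl, would follow the step to compound 2 or the step to compound 4 on either core. They also leave open whether changes at other places on these two cores diverge in the same way.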